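A few compounds are considered here, and "the series" means these few. Any claim that something is new, unique, unknown or untested is made for them only; others in the source may bear on it.

Measured compounds in an assay on microsomes from liver (strain Wistar) for inhibition of acyl-CoA desaturase 1 (Rattus norvegicus), read by HPLC, with stated times of 1 h and 60 min; a higher number here means a weaker inhibitor, a lower number a stronger inhibitor:
compound 1 `NC(=O)c1nc(N2CCC(Oc3ccccc3C(F)(F)F)CC2)no1` gives 1630 nM
compound 2 `NC(=O)c1n[nH]c(N2CCC(Oc3ccccc3C(F)(F)F)CC2)n1` gives 127 nM
compound 3 `NS(=O)(=O)c1cnc(N2CCC(Oc3ccccc3C(F)(F)F)CC2)s1` gives 41 nM

Compound 3 stands lowest of the three in this assay; compound 2 comes nearest, compound 1 lies furthest away. Among the compounds with values here, the only step between neighbours, a 13-fold lower number from compound 1 to compound 2 (1.11 log units; beyond the scatter), concerns the group on the amine nitrogen and so bears little on the change now considered. Compound 4 `OCc1nc(-c2cnc(N3CCC(Oc4ccccc4C(F)(F)F)CC3)s2)no1` differs from compound 3 by 5-(hydroxymethyl)-1,2,4-oxadiazol-3-yl in place of sulfamoyl on an aromatic carbon. Within the data shown here, no measured pair speaks to a swap at this aromatic carbon, so no direction can be taken from the data; a step of a 1.4-fold lower number from compound 3 to compound 4 (0.14 log units; within the scatter) is expected, within the scatter. Compound 4 is therefore estimated at 30 nM in this assay, with a range from 8 nM to 120 nM.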

Compound 4, half-maximal inhibitory concentration: 1 nM
Beside the measured number, compound 4's estimate is 30-fold (1.48 log units) above it; measured number outside the range, below it.
By their numbers in this assay, from the lowest: compound 4; then compound 3; then compound 2; then compound 1.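

In this assay, within the data shown here, the aromatic carbon next to the ring sulfur proves open to far more than sulfamoyl: with 5-(hydroxymethyl)-1,2,4-oxadiazol-3-yl there, a 41-fold lower number from compound 3 to compound 4 (1.61 log units; beyond the scatter) is a large step, and no earlier compound carried a swap at this carbon. Nothing measured here accounts for this gain. The compounds shown leave open whether the aromatic ring itself or its hydroxymethyl carries the step. A methyl or an aminomethyl group in place of that hydroxymethyl, or a carboxylic acid on this carbon, would bear on that question.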